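A few compounds are considered here, and "the series" means these few. Any claim that something is new, unique, unknown or untested is made for them only; others in the source may bear on it.

Three measured compounds share one core and differ only in the group carried on the benzyl ring. Compound 1 is `Cc1noc(-c2nc(C)c3c(c2N)C(=O)N(Cc2ccc(Cl)cc2)C3=O)n1`. In a physicochemical assay for solubility, using the shake flask method, in simulated intestinal fluid, measured as kinetic solubility, with a stated time of 2 h, at 25 degrees C, at pH 6.5 (a lower number here means a less soluble compound, a higher number a more soluble compound), compound 1 gives < 5000 nM, which is a limit of the assay rather than a number. Compound 2 is `Cc1noc(-c2nc(C)c3c(c2N)C(=O)N(Cc2ccc(C(F)(F)F)cc2)C3=O)n1`, and in this assay compound 2 gives < 5000 nM, again a limit. Compound 3 is `Cc1noc(-c2nc(C)c3c(c2N)C(=O)N(Cc2ccccc2Cl)C3=O)n1`, and in this assay compound 3 gives < 5000 nM, once more a limit. The change from compound 1 to compound 2 is trifluoromethyl in place of chloro on an aromatic carbon, and its step is a step that the two limits leave unreadable from compound 1 to compound 2. The two cores of compound 1 and compound 3 differ as 2-chlorophenyl in place of 4-chlorophenyl on a saturated chain carbon bound to an amide-type nitrogen in a ring.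

Compound 4, `Cc1noc(-c2nc(C)c3c(c2N)C(=O)N(Cc2ccccc2C(F)(F)F)C3=O)n1`, has not yet been measured. It differs from compound 3 by trifluoromethyl in place of chloro on an aromatic carbon; this is the same kind of change as from compound 1 to compound 2, but here the place is ortho to a large group rather than para to a large group. Because every shown value sits at the limit of < 5000 nM in this assay, at which 3 of the 3 values shown sit, compound 4 is expected to give 2500 nM in this assay, most likely again as a limit, within 500 nM to 5000 nM, and the step from compound 3 is expected to be a step that the limit leaves unreadable from compound 3 to compound 4.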

Compound 4, solubility: < 5000 nM
Compound 4 gave a limit, no number; the forecaster's own chance of this, stated with the estimate: 85%; the middle value lies beyond the limit too.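

In this assay compound 4 gives < 5000 nM, which is a limit and not a number. No step from compound 1, compound 2 or compound 3 to compound 4 can be read, as the whole set stands at one limit: the limit of < 5000 nM in this assay, at which 4 of the 4 values shown sit.

The compounds shown leave open how far apart their true values lie in this assay.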